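The source may hold more compounds than are shown below. What is called first, only, known or untested is meant among the compounds shown, and "the series" means these compounds.

Measured compounds:
compound 1, `CO/C(O)=C(/C=N/c1ccc(Oc2ccccc2OC(C)C)nc1)NC(=O)c1ccccc1`, giving 2% in a functional assay on RPTEC cells (Homo sapiens), tested at 0.1 uM; on this read-out lower numbers stand for less inhibition and higher numbers for more inhibition at the one concentration tested (going by the name of the read-out)
compound 2, `Cc1c(Cc2c(Cl)cccc2Cl)c(=O)oc2cc(OCC(=O)OCC(=O)c3ccc(Cl)cc3)ccc12`, giving 16% in this assay

Of these two numbers, compound 2 stands highest; its nearest neighbour, compound 1, lies lower by a margin beyond the usual scatter of repeated runs. No stepwise comparison between the measured compounds can be drawn. The two measured structures differ in more than one place. Compound 3, `Cc1c(Cc2c(Cl)cccc2Cl)c(=O)oc2cc(OCC(=O)OCC(=O)c3ccccc3)ccc12`, has not yet been measured. It differs from compound 2 in one place: hydrogen in place of chloro on an aromatic carbon. The chloro group leaves from an aromatic carbon of a six-membered aromatic ring of carbon only, and hydrogen enters in its place. Within the data shown here, with no measured pair showing what this change does here, the expected step of a number 4 percentage points lower from compound 2 to compound 3 (within the scatter) is small and is not expected to exceed the scatter. Compound 3 is therefore estimated to give 12% in this assay, within a range from -5% to 30%.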

Compound 3, a percentage reported as inhibition, at one concentration (the size of the read-out at that concentration, not a potency): 35%
The estimate for compound 3 lay 23 percentage points below the measured number; the measured number lies above the stated range.
By their numbers in this assay, from the lowest: compound 1; then compound 2; then compound 3.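

In this assay, among these compounds, the pair compound 2 and compound 3 gives the first comparison that differs in one place, and it shows that this position, on an aromatic carbon para to a large group, is not indifferent: going from 4-chlorophenyl to phenyl gives a number 19 percentage points higher from compound 2 to compound 3 (beyond the scatter) at the one concentration tested. At this place, then, the chloro group is not needed for the read-out, and hydrogen in its place reads higher on this single pair. No measurement shown bears on why the step runs in this direction.

The compounds shown leave open how another group at this place, such as a fluoro or an amine, would read against hydrogen and chloro. They also leave open whether the same change would give a step of similar size on a different core, such as that of compound 1.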